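The source may hold more compounds than are shown below. What is called first, only, known or untested is meant among the compounds shown, and "the series" means these compounds.

In a physicochemical assay for solubility, at pH 2 (on this read-out higher numbers stand for higher solubility and lower numbers for lower solubility), compound 1 `COc1ccc(C(=O)/C=C/c2ccc(OCCNc3ccnc4cc(Cl)ccc34)c(OC)c2)c(OC)c1` reaches only the limit of > 100 ug/mL, a boundary of the assay rather than a number. Compound 2 `COc1ccc(C(=O)/C=C/c2ccc(O)c(CN3CCN(c4ccnc5cc(Cl)ccc45)CC3)c2)c(OC)c1` likewise stops at the limit of > 100 ug/mL in this assay. Both compounds sit at the same boundary (the limit of > 100 ug/mL in this assay, at which 2 of the 2 values shown sit), which places compound 2 as high as this assay reports. Compound 3 `COc1ccc(C(=O)/C=C/c2cc(CN3CCN(c4ccnc5cc(Cl)ccc45)CC3)c(O)c(OC)c2)c(OC)c1` differs from compound 2 by methoxy in place of hydrogen on an aromatic carbon, a methoxy in place of hydrogen on an aromatic carbon. Compound 3 is expected to show no step beyond the scatter, an estimated step that the limit leaves unreadable from compound 2 to compound 3 in this assay. Compound 3 is expected to give 150 ug/mL, within 60 ug/mL to 350 ug/mL.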

Compound 3, solubility: > 100 ug/mL
Compound 3: no number, only a limit; the forecaster's own chance of this, stated with the estimate: 75%; the middle value lies beyond the limit too.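

Compound 2 and compound 3 both stop at the same limit in this assay, so no step can be read between them: the limit of > 100 ug/mL in this assay, at which 3 of the 3 values shown sit.

The compounds shown leave open whether methoxy in place of hydrogen changes the true solubility at all.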